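Notes on the shared core: amino in place of chloro

A few compounds are considered here, and "the series" means these few. Any claim that something is new, unique, unknown or untested is made for them only; others in the source may bear on it.

Measured so far in a functional assay on SW-620 cells (Homo sapiens) for inhibition; on this read-out higher numbers stand for weaker inhibition and lower numbers for stronger inhibition:
compound 1 `CC(=O)OC(C)n1cnc2c(Cl)nc(I)nc21` gives 3550 nM.
compound 2 `CC(=O)OCCOn1cnc2c(Cl)nc(I)nc21` gives 15800 nM.
compound 3 `CC(O)n1cnc2c(Cl)nc(I)nc21` is reported only as a limit, > 500000 nM.

Compounds 1 and 2 both return numbers in this assay; compounds 1 and 3 differ in one place, hydrogen in place of acetyl on an oxygen on a saturated carbon, and give an at least 140-fold higher number from compound 1 to compound 3 (2.14 log units; beyond the scatter). Compound 3 thus stands at the limit of this assay, (the limit of > 500000 nM in this assay, at which 1 of the 3 values shown sits), with no number of its own.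

The next compound, compound 4 `CC(O)n1cnc2c(N)nc(I)nc21`, is not yet measured. Its change from compound 3 is amino in place of chloro on an aromatic carbon. Among the measured compounds shown here, none of the measured steps concerns this position or this exchange; the only measured step, an at least 140-fold higher number from compound 1 to compound 3 (2.14 log units; beyond the scatter), touches the side chain instead. There is therefore no measured basis for expecting a step beyond the scatter in this assay, and the starting point is itself a limit. Compound 4 is expected to remain at or near the limit, with an estimate of about 500000 nM and a range from 100000 nM to 2000000 nM. The implied step a number no higher from compound 3 to compound 4 (the limit leaves the size open) is the expectation, not a measurement.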

Compound 4, half-maximal inhibitory concentration: > 500000 nM
Compound 4 gave a limit, no number (the forecaster's own chance of this, stated with the estimate: 70%); the middle value lies on the limit itself.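

In this assay compound 3 and compound 4 are both limits, not numbers, so amino in place of chloro gives no readable step between them. The compounds shown leave open what this exchange does where the parent compound returns a number, as compound 1 does.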